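Methyl on a Phenyl Ring in Two Thiophene Series

The source may report more compounds than this note shows. Statements on the series, on what has been measured and on what is new or still open speak of the compounds shown alone.

Compound 1 `COc1cc(OC)cc(C(=O)NNC(=S)Nc2csc(-c3ccccc3)c2)c1` and compound 2 `COc1cc(OC)cc(C(=O)NNC(=S)Nc2csc(-c3ccc(C)cc3)c2)c1` share one core, and the two differ by a single change (methyl in place of hydrogen on an aromatic carbon). In a functional assay on U-373MG ATCC cells (Homo sapiens) for inhibition, read by colorimetric assay and MTT assay, with a stated time of 72 h (a lower number here means a stronger inhibitor, a higher number a weaker inhibitor), compound 1 gives 40000 nM. In this assay compound 2 gives 41000 nM. The step itself is a 1.0-fold higher number from compound 1 to compound 2 (0.01 log units; within the scatter), so the two compounds cannot be told apart by this measurement.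

Compound 3 `Oc1ccc(-c2nnc(Nc3csc(-c4ccccc4)c3)s2)cc1` carries a different core; how it differs from compound 1 is not broken down here. In this assay compound 3 gives 58000 nM, which lies within the scatter of both earlier compounds, so no order among the three can be claimed.

Compound 4 `Cc1ccc(-c2cc(Nc3nnc(-c4ccc(O)cc4)s3)cs2)cc1` is not yet measured. It differs from compound 3 by methyl in place of hydrogen on an aromatic carbon, the same change already seen between compound 1 and compound 2, at the same kind of place on a six-membered aromatic ring of carbon only, para to a large group. The expected step for compound 4 is a 1.0-fold higher number from compound 3 to compound 4 (0.01 log units; within the scatter), because a 1.0-fold higher number from compound 1 to compound 2 (0.01 log units; within the scatter) shows that this change left the number essentially untouched in the other core. That rests on one pair only, and the core is different, so the expectation is loose. In this assay compound 4 is expected to give about 60000 nM, with a likely range from 30000 nM to 120000 nM.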

Compound 4, half-maximal inhibitory concentration: 8000 nM
The estimate for compound 4 lay 7.5-fold (0.88 log units) above the measured number; the whole stated range lies above it.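

In this assay, replacing phenyl with 4-methylphenyl on the second core gives a 7.3-fold lower number from compound 3 to compound 4 (0.86 log units; beyond the scatter), a clear shift from a change that made no measurable difference on the first core. Set side by side, the two results for the same small change do not agree: the same change on two cores in this assay, a 1.0-fold higher number (0.01 log units; within the scatter) from compound 1 to compound 2 and a 7.3-fold lower number (0.86 log units; beyond the scatter) from compound 3 to compound 4, 7.4-fold (0.87 log units) apart, beyond the scatter of two such steps

This shows that the effect of this methyl cannot be carried from one core to the other in this series as a fixed amount, so a step read on one core is a poor guide to the same step on the other. Among the compounds shown here, it does not show why the two cores respond differently, and with only one pair on each core, it gives no general rule for other cores or other groups.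

The compounds shown carry only hydrogen or methyl at this place on the phenyl ring, so it remains open whether an ethyl group, a chlorine atom or an amine there would give a lower number on the core of compound 3. From the compounds shown here alone, it also remains open whether any of these groups would shift the number on the core of compound 1, where methyl made no measurable difference.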